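The compounds below may be only part of what the source reports. "The series", "measured", "known", "first", "only" and "open" are said of these compounds alone.

In a single whole-organism screen, two diamino compounds built on the same core were compared. The read-out was a functional assay on the whole organism with Rattus norvegicus as the target, at a dose of 20 mg/kg by the intraperitoneal route; a higher number here means more inhibition at the dose given (going by the name of the read-out), a lower number less inhibition. Compound 1, `COc1ccc(Br)cc1-c1nc(N)nc(N)n1`, gives 49% in this assay. Compound 2, `Nc1nc(N)nc(-c2cc(F)ccc2Br)n1`, gives 78% in this assay. Compound 2 therefore stands highest of the two numbers recorded so far, and the gap down to compound 1 lies beyond the usual scatter of this assay; since the two structures differ in more than one place, nothing more than that comparison of values can be drawn from them.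

The next compound to be measured is compound 3, `Nc1nc(N)nc(-c2cc(Br)ccc2Br)n1`. Its relation to compound 2 is a single exchange: bromo in place of fluoro on an aromatic carbon. For the measured compounds named here, no pair of measured compounds isolates this kind of exchange, so there is no measured precedent for the size of the step. The expectation is that the step in this assay will be small, in either direction, most likely none beyond the scatter. Compound 3 is thus expected to give about 75% in this assay, with a range from 55% to 92%. The expected step is a number 3 percentage points lower from compound 2 to compound 3 (within the scatter).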

Compound 3, a percentage reported as inhibition, in the whole organism at one dose (the size of the read-out at that dose, not a potency) in the Rattus norvegicus assay: 43%
Beside the measured number, compound 3's estimate is 32 percentage points above it; measured number outside the range, below it.
By their numbers in the Rattus norvegicus assay, from the lowest: compounds 3 and 1 (each within the scatter of the next); then compound 2.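

The result shows that this aromatic carbon, para to a bromo group, is sensitive to a change of a single halogen: in the Rattus norvegicus assay the exchange gives a number 35 percentage points lower from compound 2 to compound 3 (beyond the scatter), whereas the exchange of methoxy for bromo at the same carbon gives a number 6 percentage points lower from compound 1 to compound 3 (within the scatter), so compound 3 and compound 1 cannot be told apart here, and only the fluoro compound stands clear of the bromo compound in a comparison at this one place. In a physicochemical assay for lipophilicity (on this read-out higher numbers stand for higher lipophilicity and lower numbers for lower lipophilicity), compound 2 gives 1.45 and compound 3 gives 2.09, a change of a number 0.64 log units higher from compound 2 to compound 3 (beyond the scatter). In this single pair, higher lipophilicity therefore comes with lower inhibition, which is a coincidence of two read-outs and not yet a demonstrated cause: the measured partition coefficient of compound 2, 1.45, and of compound 3, 2.09, a number 0.64 log units higher (beyond the scatter)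

The compounds shown leave open whether inhibition at the dose given follows lipophilicity at this carbon in general, since one pair cannot separate that from anything else that sets fluoro and bromo apart. A chloro group, a methyl group or an amine on the same carbon would be needed to show whether the high value of compound 2 is particular to fluoro.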